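Series notes: aryl-for-alkyl exchange on the shared core

The source may hold more compounds than are shown below. What is called first, only, known or untested is meant among the compounds shown, and "the series" means these compounds.

Measured so far:
compound 1 `CC(C)Cc1ccc2c(NCCCNCc3ccco3)ccnc2c1` — 23 10^-6 cm/s in an ADME assay for permeability, using PAMPA, with a stated time of 30 min, at pH 7.4; on this read-out higher numbers stand for higher permeability and lower numbers for lower permeability
compound 2 `COc1cccc(Oc2ccc3c(NCCCNCc4ccco4)ccnc3c2)c1` — 317 10^-6 cm/s in this assay

For the measured compounds named here, compound 1 gives the lower of the two numbers measured in this assay; its only neighbour is compound 2, reached by a 14-fold higher number from compound 1 to compound 2 (1.14 log units; beyond the scatter), with 3-methoxyphenoxy in place of isobutyl on an aromatic carbon.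

Compound 3 `FC(F)(F)c1cccc(Cc2ccc3c(NCCCNCc4ccco4)ccnc3c2)c1` has not been measured in this assay. It differs from compound 1 by 3-(trifluoromethyl)phenyl in place of isopropyl on a saturated chain carbon bound to an aromatic carbon.

Going by the values given here, only the step from compound 1 to compound 2 bears on this change: there isobutyl gave way to 3-methoxyphenoxy and the number rose by a large step. Compound 3 is therefore expected to show a rise beyond the scatter in this assay, a 6.5-fold higher number from compound 1 to compound 3 (0.81 log units; beyond the scatter), though the entering group is not the same and the size is uncertain. Compound 3 is estimated at 150 10^-6 cm/s, with a range of 50 10^-6 cm/s to 400 10^-6 cm/s.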

Compound 3, apparent permeability: 23 10^-6 cm/s
The estimate for compound 3 lay 6.5-fold (0.81 log units) above the measured number; measured number below the stated range.
By their numbers in this assay, from the lowest: compounds 1 and 3 (each within the scatter of the next); then compound 2.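

In this assay there is no change at the digits printed from compound 1 to compound 3 (within the scatter) with 3-(trifluoromethyl)phenyl in place of isopropyl, so a larger group carrying a six-membered aromatic ring can enter on this saturated chain carbon without moving the number beyond the scatter. An aromatic ring in the entering group is therefore not enough on its own to give a higher number on the shared core. The rise seen as a 14-fold higher number from compound 1 to compound 2 (1.14 log units; beyond the scatter) with 3-methoxyphenoxy in place of isobutyl forms no general aryl-for-alkyl pattern, and compound 3 goes against it. Nothing available explains why the two exchanges part ways.

Open, from the compounds shown here alone, is whether the rise follows the ether oxygen of 3-methoxyphenoxy or its methoxy group. Also open, going by these compounds, is how an amine, a carboxylic acid or a longer chain would behave at this place.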